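The source may report more compounds than this note shows. Statements on the series, on what has been measured and on what is new or still open speak of the compounds shown alone.

In a functional assay on PC-3 cells (Homo sapiens) for cytotoxicity, read by sulforhodamine B assay, with a stated time of 72 h (on this read-out lower numbers stand for stronger inhibition and higher numbers for weaker inhibition), compound 1 `COC(=O)c1c(N)sc(-c2ccc(Cl)cc2)c1-c1ccc(Cl)cc1` gives 2780 nM, the lowest of the two numbers obtained so far. Compound 2 `Nc1sc(-c2ccc(Br)cc2)c(-c2ccc(Cl)cc2)c1C(=O)N1CCCC1` gives 37500 nM in this assay, a much higher number, well beyond the scatter. Compound 3 `Nc1sc(-c2ccc(Cl)cc2)c(-c2ccc(Cl)cc2)c1C(=S)NC1CCCCC1` has not yet been measured. It differs from compound 1 in one place: a group of 9 heavy atoms (7 carbon, 1 nitrogen, 1 sulfur; one six-membered non-aromatic ring of carbon only) in place of a group of 4 heavy atoms (2 carbon, 2 oxygen; no ring), on an aromatic carbon. Among the measured compounds shown here, no measured pair shows this same change, so its effect cannot be read from the data; a step of moderate size toward weaker inhibition is expected, though the range is wide. Compound 3 is estimated to give about 8000 nM, between 2500 nM and 30000 nM. The expected step is a 2.9-fold higher number from compound 1 to compound 3 (0.46 log units; beyond the scatter).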

Compound 3, half-maximal inhibitory concentration: 27700 nM
Estimate against measurement, compound 3: 3.5-fold (0.54 log units) below, and the stated range covers the measured number.
By their numbers in this assay, from the lowest: compound 1; then compounds 3 and 2 (each within the scatter of the next).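

This position is sensitive to what it carries: in this assay, putting the larger group with its six-membered carbon ring in place of methoxycarbonyl gives a 10-fold higher number from compound 1 to compound 3 (1.00 log units; beyond the scatter) on otherwise identical compounds. On this core, then, that group does not stand in for the ester without a clear loss of inhibition. Nothing measured here bears on why.

Still open, from the compounds shown here alone, is which part of the new group matters: its sulfur, its ring or its size. A carboxylic acid or a simple amide without the ring could separate these.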